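A Fluorine Added to the Core of Compound 2

The source may report more compounds than this note shows. Statements on the series, on what has been measured and on what is new or still open speak of the compounds shown alone.

Compound 2, with structure `CO/N=C/c1c(N)ncnc1Oc1ccc2[nH]ccc2c1`, is one of three compounds tested in a functional assay on A-375 cells (Homo sapiens) for antiproliferative activity; on this read-out lower numbers stand for stronger inhibition and higher numbers for weaker inhibition. In this assay compound 2 gives 783 nM. Compound 1, `CO/N=C/c1c(N)ncnc1Oc1ccc2cccnc2c1`, gives 886 nM, a number that lies within the scatter of that of compound 2. Compound 3, `CO/N=C/c1c(N)ncnc1Oc1ccc2[nH]cc(C)c2c1`, gives 132 nM. For the measured compounds named here, the only single change measured so far is a 5.9-fold lower number from compound 2 to compound 3 (0.77 log units; beyond the scatter).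

The compound now in question is compound 4, `CO/N=C/c1c(N)ncnc1Oc1ccc2[nH]ccc2c1F`. Set against compound 2 it shows (fluoro in place of hydrogen on an aromatic carbon). Going by the values given here, that one measured step swaps hydrogen for methyl, not for fluoro, so it gives no direct guide to the present change, and no other measured pair involves a fluoro entering. With nothing to point either way, a small step is the most reasonable expectation. Compound 4 is expected to show a step of a 1.1-fold lower number from compound 2 to compound 4 (0.05 log units; within the scatter), which stays within the usual scatter. Compound 4 is therefore estimated at 700 nM, with a range from 250 nM to 2000 nM.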

Compound 4, half-maximal inhibitory concentration: 492 nM
Compound 4: middle estimate off by 1.4-fold (0.15 log units), on the high side; the range from low to high includes it.
By their numbers in this assay, from the lowest: compound 3; then compounds 4, 2 and 1 (each within the scatter of the next).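

In this assay, fluoro in place of hydrogen gives a 1.6-fold lower number from compound 2 to compound 4 (0.20 log units; within the scatter), so at this aromatic carbon, ortho to a fused ring and ortho to a large group, the change cannot be told apart from repeat-measurement noise. For the compounds shown here, the earlier compounds said nothing about this carbon: their one single change, a 5.9-fold lower number from compound 2 to compound 3 (0.77 log units; beyond the scatter), put a methyl on a different carbon, and that step does lie beyond the scatter. Nothing measured here bears on the reason for either result.

As far as these compounds go, a single fluorine atom says little about what a chloro, a methoxy or an amine would do at this same carbon, so how much this position accepts remains open. Also open, from the compounds shown here alone, is whether a compound carrying both this fluoro and the methyl of compound 3 would keep the number seen for compound 3, 132 nM.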